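Solubility of a dimethylaminophenoxy analogue, estimated from three measurements

A few compounds are considered here, and "the series" means these few. Any claim that something is new, unique, unknown or untested is made for them only; others in the source may bear on it.

Measured compounds:
compound 1, `COc1ccc(F)cc1CNCCCNc1ccnc2cc(CC(C)C)ccc12`: 4200 nM in a physicochemical assay for solubility, with a stated time of 18 h, at pH 7.4; a lower number here means a less soluble compound, a higher number a more soluble compound
compound 2, `COc1ccc(F)cc1CNCCCNc1ccnc2cc(Cc3ccc(F)cc3)ccc12`: 4200 nM in this assay
compound 3, `COc1ccc(-c2ccc3c(NCCCNCc4cc(F)ccc4OC)ccnc3c2)cc1`: 32000 nM in this assay

Compound 3 stands highest of the three in this assay: the steps of a 7.6-fold higher number from compound 1 to compound 3 (0.88 log units; beyond the scatter) and a 7.6-fold higher number from compound 2 to compound 3 (0.88 log units; beyond the scatter) are both beyond the scatter, whereas no change at the digits printed from compound 1 to compound 2 (within the scatter). Compound 4, `COc1ccc(F)cc1CNCCCNc1ccnc2cc(Oc3cccc(N(C)C)c3)ccc12`, has not yet been measured. It differs from compound 3 as follows: 3-(dimethylamino)phenoxy in place of 4-methoxyphenyl on an aromatic carbon. For the measured compounds named here, no measured step exchanges one aryl-type substituent for another at this aromatic carbon; the closest guidance comes from the steps to compound 3, which show that a change at this position can move the read-out modestly while the rest of the molecule is held. Because compound 3 already gives 32000 nM, and because the group entering in compound 4 carries the larger count of hydrogen-bond acceptors given in the change described, compound 4 is expected to stay near or somewhat above it, a step of a 1.4-fold higher number from compound 3 to compound 4 (0.15 log units; within the scatter). Compound 4 is therefore estimated at 45000 nM, within 13000 nM to 150000 nM.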

Compound 4, solubility: 14500 nM
The estimate for compound 4 lay 3.1-fold (0.49 log units) above the measured number; the range from low to high includes it.
By their numbers in this assay, from the lowest: compounds 1 and 2 (each within the scatter of the next); then compound 4; then compound 3.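

For the compounds shown here, compound 4 gives the first exchange of one aryl-type group for another at this aromatic carbon, and in this assay 3-(dimethylamino)phenoxy in place of 4-methoxyphenyl gives a 2.2-fold lower number from compound 3 to compound 4 (0.34 log units; beyond the scatter) in a step beyond the scatter. The new group still reads clearly above both earlier alkyl-type and benzyl-type groups, with a 3.5-fold higher number from compound 1 to compound 4 (0.54 log units; beyond the scatter) against isobutyl and a 3.5-fold higher number from compound 2 to compound 4 (0.54 log units; beyond the scatter) against 4-fluorobenzyl so that the order at this position now has four distinct compounds in three levels. The larger count of hydrogen-bond acceptors in the entering group did not go with a higher number here, and no measurement is available that accounts for this order.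

The compounds shown do not separate the oxygen link from the dimethylamino group in this change. From the compounds shown here alone, how an unsubstituted phenoxy or a carboxylic acid on that ring would stand in this assay remains open.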